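The compounds below may be only part of what the source reports. "The series", "measured", "known", "first", "only" and "open" are said of these compounds alone.

Measured compounds in this study:

compound 1, `ClCc1cccc(Cn2cnc3c(Cl)nc(Cl)nc32)c1` — > 100000 nM
compound 2, `Nc1nc(Cl)c2ncn(Cc3ccc(CCl)cc3)c2n1` — > 100000 nM
compound 3, `ClCc1ccccc1Cn1cnc2nc(Cl)nc(Cl)c21` — 930 nM

Of the compounds shown here, three have been measured in a functional assay on CCRF-CEM cells (Homo sapiens) for cytotoxicity, read by sulforhodamine B assay, with a stated time of 48 h; a lower number here means that less compound is tolerated, a higher number that more compound is tolerated. Compound 1 reaches only the limit of > 100000 nM in this assay, which is not a number but the edge of the measurement. Compound 2 likewise stops at the limit of > 100000 nM. Compound 3 alone gives a number, 930 nM. Compound 1 thus stands at the weak end of what is shown: the limit of > 100000 nM in this assay, at which 2 of the 3 values shown sit. Within the data shown here, no pair among the three differs in a single place, so no step can be read from them directly.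

Compound 4, `Nc1nc(Cl)c2ncn(Cc3cccc(CCl)c3)c2n1`, has not yet been measured. It differs from compound 1 in one place: amino in place of chloro on an aromatic carbon. Among the measured compounds shown here, compound 2 also carries the amino group and gives no number in this assay, while the only numbered value belongs to compound 3, whose structure differs from compound 4 in more than one place. On that basis compound 4 is expected to remain at the edge of the measurement, and the estimated step of a number no higher from compound 1 to compound 4 (the limit leaves the size open) is none beyond the scatter. The expected value for compound 4 is 100000 nM, with a range from 30000 nM to 300000 nM.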

Compound 4, concentration lethal to 50% of the cells: > 100000 nM
Compound 4: only a limit was reported; the forecaster's own chance of this, stated with the estimate: 75%; the middle value sits exactly at the limit.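

Among these compounds, compound 1 and compound 4 both give only limits in this assay, so no step between them can be read. Compound 4 thus ends at a limit and not a number: the limit of > 100000 nM in this assay, at which 3 of the 4 values shown sit.

The compounds shown leave open how far amino in place of chloro on an aromatic carbon shifts the value, and whether any compound carrying the amino group gives a number in this assay.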